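Sulfonyl substituent exchange in a small amide-acid series

The source may report more compounds than this note shows. Statements on the series, on what has been measured and on what is new or still open speak of the compounds shown alone.

Measured so far:
Compound 1 `O=C(Nc1ccc(S(=O)(=O)NC2CCCCC2)cc1)C1C(C(=O)O)[C@H]2CC[C@@H]1O2`: in a functional assay on HCT-8 cells (Homo sapiens) for cytotoxicity, read by MTT assay, with a stated time of 48 h (a lower number here means a stronger inhibitor, a higher number a weaker inhibitor), compound 1 gives 31000 nM.
Compound 2 `O=C(Nc1ccc(S(=O)(=O)N2CCOCC2)cc1)C1C(C(=O)O)[C@H]2CC[C@@H]1O2`: in this assay compound 2 gives 31300 nM.

Compound 2 stands level with compound 1: the step of a 1.0-fold higher number from compound 1 to compound 2 (0.00 log units; within the scatter) is within the scatter, so the two numbers cannot be told apart. That step exchanged cyclohexylamino for morpholin-4-yl on the sulfonyl sulfur without any effect beyond the scatter.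

Compound 3 `O=C(Nc1ccc(S(=O)(=O)NC2CCCC2)cc1)C1C(C(=O)O)[C@H]2CC[C@@H]1O2` is not yet measured. It differs from compound 2 by cyclopentylamino in place of morpholin-4-yl on a sulfonyl sulfur. For the measured compounds named here, the only step that bears on this is a 1.0-fold higher number from compound 1 to compound 2 (0.00 log units; within the scatter), which showed that replacing a cycloalkylamino group by morpholin-4-yl at this position left the number unchanged; compound 3 reverses that direction with a smaller ring, cyclopentylamino, carrying the same hydrogen-bond donor as cyclohexylamino in compound 1. On that basis no step beyond the scatter is expected in this assay.

Compound 3 is therefore estimated at 31000 nM, within 15000 nM to 62000 nM, the expected step of a 1.0-fold lower number from compound 2 to compound 3 (0.00 log units; within the scatter) being within the scatter.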

Compound 3, half-maximal inhibitory concentration: 30200 nM
For compound 3 the middle estimate is 1.0-fold (0.01 log units) above the measured one; low and high end bracket the measured number.
By their numbers in this assay, from the lowest: compounds 3, 1 and 2 (each within the scatter of the next).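

In this assay, the step of a 1.0-fold lower number from compound 1 to compound 3 (0.01 log units; within the scatter) adds a comparison the earlier pair did not offer: two cycloalkyl groups on the sulfonamide nitrogen, differing only in ring size, cannot be told apart. The step of a 1.0-fold lower number from compound 2 to compound 3 (0.02 log units; within the scatter) brings in a hydrogen-bond donor and removes a hydrogen-bond acceptor, and it also stays within the scatter, so across compounds 1, 2 and 3 neither ring size nor the exchange between morpholin-4-yl and a cycloalkylamino group separates the numbers at this position on the sulfonyl sulfur. No measurement at hand accounts for this flat response.

From the compounds shown here alone, all three compounds carry a saturated ring on the sulfonyl sulfur, so it remains open whether an unsubstituted amino group, an open-chain butylamino group or an anilino group would give a step beyond the scatter. The amide and the carboxylic acid on the shared core are also constant throughout, leaving open whether a methyl ester in place of that acid would move the number in this assay.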